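Cytotoxicity notes: amide nitrogen substituents on a shared core

The source may report more compounds than this note shows. Statements on the series, on what has been measured and on what is new or still open speak of the compounds shown alone.

Measured in an ADME assay on SW480 cells (Homo sapiens) for cytotoxicity, read by MTT assay, with a stated time of 72 h (a lower number here means a stronger inhibitor, a higher number a weaker inhibitor), so far:
compound 1, `CCc1ccc(NC(=O)c2cccc(/C=C3\CC(=O)N(c4ccccc4)C3=O)c2)cc1`, a limit at > 100000 nM
compound 2, `CCc1cccc(NC(=O)c2cccc(/C=C3\CC(=O)N(c4ccccc4)C3=O)c2)c1`, 88600 nM
compound 3, `COc1ccc(NC(=O)c2cccc(/C=C3\CC(=O)N(c4ccccc4)C3=O)c2)c(C)c1`, a limit at > 100000 nM

Compound 3 stands at a limit of this assay, not at a number, and it shares that position with one other entry, as the limit of > 100000 nM in this assay, at which 2 of the 3 values shown sit, records. The steps among the measured compounds say little: an at least 1.1-fold lower number from compound 1 to compound 2 (0.05 log units; that floor lies within the scatter), an at least 1.1-fold higher number from compound 2 to compound 3 (0.05 log units; that floor lies within the scatter), and a step that the two limits leave unreadable from compound 1 to compound 3. None of them is readable beyond the scatter.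

Compound 4 is `O=C(NCC1CCCCC1)c1cccc(/C=C2\CC(=O)N(c3ccccc3)C2=O)c1`. It differs from compound 3 by cyclohexylmethyl in place of 4-methoxy-2-methylphenyl on an amide-type nitrogen. Within the data shown here, no measured step bears directly on a change of this kind, and the three measured steps around compound 3 all sit inside the scatter or are unreadable, so no step beyond the scatter is expected here. Compound 4 is expected to give 120000 nM in this assay, with a range from 40000 nM to 400000 nM. This estimate means a step that the limit leaves unreadable from compound 3 to compound 4, and a limit rather than a number is the likelier outcome for compound 4.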

Compound 4, half-maximal inhibitory concentration: > 100000 nM
Compound 4 was reported as a limit (the forecaster's own chance of this, stated with the estimate: 65%); the middle value lies beyond the limit too.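

In this assay the amide-type nitrogen now carries cyclohexylmethyl, a non-aromatic ring of carbon only, and compound 4 still gives a limit, > 100000 nM, rather than a number. Among these compounds, the one readable step is an at least 1.1-fold higher number from compound 2 to compound 4 (0.05 log units; that floor lies within the scatter), and the steps to the other two compounds cannot be read. Moving from an aromatic to a non-aromatic ring at this position therefore gives no step beyond the scatter, and the series remains concentrated at a single reading: the limit of > 100000 nM in this assay, at which 3 of the 4 values shown sit.

Still open, on these data alone, is whether any group on the amide-type nitrogen can bring a value clearly inside the range of this assay. The compounds shown include no basic amine such as a 2-aminoethyl group and no carboxylic acid there, so neither kind of substituent can be judged from these data.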